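The source may hold more compounds than are shown below. What is called first, only, known or untested is meant among the compounds shown, and "the series" means these compounds.

Compound 1 `COc1ccc2cc(-c3ccccc3)c(O)nc2c1`: 10000 nM
Compound 2 `COc1ccc(-c2cc3c(OC)cc(OC)cc3n(CC#N)c2=O)cc1`: 10000 nM

Going by the values given here, only two compounds have been measured so far, and they do not separate. In a functional assay on MCF7 cells (Homo sapiens) for cytotoxicity, read by colorimetric assay and MTT assay (on this read-out lower numbers stand for stronger inhibition and higher numbers for weaker inhibition), compound 1 gives 10000 nM and compound 2 gives 10000 nM, so compound 2 stands level with compound 1, within the scatter.

The next compound to be tested is compound 3 `COc1ccc(-c2cc3c(OC)cc(OC)cc3n(CCC(=O)OCc3ccccc3)c2=O)cc1`. It keeps the core of compound 2 and carries (benzyloxycarbonyl)methyl in place of cyano on a saturated chain carbon bound to an aromatic nitrogen.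

Among the compounds with values here, no two measured compounds differ in a single place, so the data hold no measured step that could show what such a change does in this assay. Within the data shown here, the only guide is the level reading of compound 2 at 10000 nM. On that basis, no change beyond the scatter is expected, and any shift would be unsupported by a measured precedent. The estimated size of the change is a 1.1-fold lower number from compound 2 to compound 3 (0.05 log units; within the scatter). For compound 3 the expected value is 9000 nM, with an estimated range of 3000 nM to 20000 nM.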

Compound 3, half-maximal inhibitory concentration: 10000 nM
For compound 3 the middle estimate is 1.1-fold (0.05 log units) below the measured one; measured number inside the range.
By their numbers in this assay, from the lowest: compounds 1, 2 and 3 (each within the scatter of the next).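

In this assay, placing (benzyloxycarbonyl)methyl in place of cyano on a saturated chain carbon bound to an aromatic nitrogen gives no change at the digits printed from compound 2 to compound 3 (within the scatter). Going by these compounds alone, this is the first measured step at this position, and it shows that the reading holds when the small nitrile gives way to a group with many more heavy atoms, one that brings in a six-membered aromatic ring of carbon only and a double bond outside aromatic rings. No measurement at hand bears on why the two compounds read alike.

The compounds shown leave open whether any group at this place can move the number in this assay, for instance a carboxylic acid or a primary amine in place of (benzyloxycarbonyl)methyl. They also leave open whether a change elsewhere on the shared core, such as a hydroxyl in place of one of its methoxy groups, would separate a compound from compound 2 at 10000 nM.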